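Amide-to-urea change on the shared core

The source may report more compounds than this note shows. Statements on the series, on what has been measured and on what is new or still open speak of the compounds shown alone.

Measured compounds:
compound 1: `CN(C(=O)c1ccccc1)c1ccc2[nH]c(-c3n[nH]c4ccccc34)cc2n1` — 12500 nM
compound 2: `COc1ccc(S(=O)(=O)N(C)c2ccc3[nH]c(-c4n[nH]c5ccccc45)cc3n2)cc1` — 13000 nM
compound 3: `COc1ccc(S(=O)(=O)N(C)c2ccc3[nH]c(-c4n[nH]c5ccccc45)cc3n2)c(OC)c1` — 10800 nM

In a functional assay on SMMC-7721 cells (Homo sapiens) for antiproliferative activity, read by MTT assay, with a stated time of 72 h (on this read-out lower numbers stand for stronger inhibition and higher numbers for weaker inhibition), compound 1 gives 12500 nM, the second highest of the three numbers. Its nearest neighbour is compound 2, and its furthest is compound 3; both of those gaps are within the scatter, so the three measured compounds cannot be told apart on this read-out. For the measured compounds named here, the only step between measured compounds that differ in one place is a 1.2-fold lower number from compound 2 to compound 3 (0.08 log units; within the scatter), a methoxy in place of hydrogen on an aromatic carbon, within the scatter and on a different part of the molecule.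

Compound 4 is `CN(C(=O)Nc1ccccc1)c1ccc2[nH]c(-c3n[nH]c4ccccc34)cc2n1`. It differs from compound 1 in one place: anilino in place of phenyl on a carbonyl carbon. Going by the values given here, no measured step touches the carbonyl carbon or the group attached to it, so there is nothing that bears directly on the change. With every step seen so far within the scatter, the working expectation is no step beyond the scatter in this assay. The expected step is no change at the digits printed from compound 1 to compound 4 (within the scatter). Compound 4 is therefore estimated at 12500 nM, with a range of 5000 nM to 31000 nM.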

Compound 4, half-maximal inhibitory concentration: 280 nM
For compound 4 the middle estimate is 45-fold (1.65 log units) above the measured one, and the stated range ends above it.
By their numbers in this assay, from the lowest: compound 4; then compounds 3, 1 and 2 (each within the scatter of the next).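

In this assay, for the compounds shown here, anilino in place of phenyl on the carbonyl carbon gives a 45-fold lower number from compound 1 to compound 4 (1.65 log units; beyond the scatter), the first step to lie beyond the scatter, whereas the methoxy change gave only a 1.2-fold lower number from compound 2 to compound 3 (0.08 log units; within the scatter). The read-out is therefore not flat across the series, and the group on this carbonyl carbon is a place where a single change moves the number strongly. The same six-membered aromatic ring of carbon only leaves and enters, so the listed difference between benzoyl and phenylcarbamoyl is the added nitrogen with its hydrogen-bond donor, although nothing available here establishes why the number moves or whether that nitrogen, its hydrogen or something else accounts for the step.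

Still open, going by these compounds, is whether the lower number survives with a phenoxy group on the same carbonyl carbon, or with an anilino whose nitrogen carries a methyl group, either of which would separate the nitrogen from its hydrogen. Also open, on these data alone, is whether a methoxy or chloro group on the anilino ring, or a benzylamino group in its place, moves the number further.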